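The compounds below may be only part of what the source reports. "The series", "measured", "known", "first", "only" and "open" are said of these compounds alone.

Measured so far:
compound 1 `C#CCn1cc(C(=O)NC(CC(=O)Nc2ccccc2)c2ccccc2)c(=O)c2cc(F)c(Cl)nc21` — > 10000 nM
compound 2 `C#CCn1cc(C(=O)NC(CC(=O)Nc2ccccn2)c2ccccc2)c(=O)c2ccc(Cl)nc21` — 5200 nM

Both compounds were run in a functional assay on KB cells (Homo sapiens) for cytotoxicity, read by MTT assay, with a stated time of 72 h; a lower number here means a stronger inhibitor, a higher number a weaker inhibitor. For compound 1 the value > 10000 nM is a limit of the assay rather than a number, so compound 1 stands at the limit of > 10000 nM in this assay, at which 1 of the 2 values shown sits. Compound 2 gives 5200 nM in this assay. For the measured compounds named here, no single-place step links compound 1 and compound 2; their two values show only what each compound gives on its own. Compound 3 `C#CCn1cc(C(=O)NC(CC(=O)NC2CCCCC2)c2ccccc2)c(=O)c2cc(F)c(Cl)nc21` is not yet measured. It differs from compound 1 by cyclohexyl in place of phenyl on an amide-type nitrogen. Going by the values given here, no measured step tells how this change acts on the shared core; the expectation is therefore a step within the usual scatter, with no direction favoured. The expected step from compound 1 to compound 3 is a step that the limit leaves unreadable from compound 1 to compound 3. Compound 3 is estimated at 12000 nM in this assay, within 3000 nM to 50000 nM, with a fair chance that the assay again reports only a limit.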

Compound 3, half-maximal inhibitory concentration: > 10000 nM
Compound 3 gave a limit, no number (the forecaster's own chance of this, stated with the estimate: 60%); the middle value does not contradict the limit.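

Compound 1 and compound 3 each return only a limit of the assay, so no step can be read for cyclohexyl in place of phenyl on an amide-type nitrogen: the limit of > 10000 nM in this assay, at which 2 of the 3 values shown sit.

Going by these compounds, how far either compound lies from that limit, and whether this change acts at all on the shared core, stays open.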